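Swapping Benzyl for 4-Methylphenyl on the Amide Nitrogen

A few compounds are considered here, and "the series" means these few. Any claim that something is new, unique, unknown or untested is made for them only; others in the source may bear on it.

Of the compounds shown here, three sharing one core have been tested in a functional assay on the whole organism for inhibition, with Rattus norvegicus as the target, read by paw edema, at a dose of 100 mg/kg by the oral route; a lower number here means less inhibition, a higher number more inhibition at the dose given (going by the name of the read-out). Compound 1 `CNC(=O)c1c(O)c2cccnc2n(-c2ccccc2)c1=O` gives 9.6% in this assay. Compound 2 `CCCCNC(=O)c1c(O)c2cccnc2n(-c2ccccc2)c1=O` gives 12.8%. Compound 3 `O=C(NCc1ccccc1)c1c(O)c2cccnc2n(-c2ccccc2)c1=O` gives 1.6%, the lowest of the three numbers, though its gap to compound 1 is within the scatter and only its gap to compound 2 is beyond it. The measured steps were a number 3.2 percentage points higher from compound 1 to compound 2 (within the scatter), a number 8 percentage points lower from compound 1 to compound 3 (within the scatter) and a number 11.2 percentage points lower from compound 2 to compound 3 (beyond the scatter); all three concern what sits on the saturated chain carbon bound to the amide-type nitrogen, and none of them exceeds a modest size.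

Compound 4 `Cc1ccc(NC(=O)c2c(O)c3cccnc3n(-c3ccccc3)c2=O)cc1` differs from compound 3 in a different way: 4-methylphenyl in place of benzyl on an amide-type nitrogen. Within the data shown here, no measured step addresses this change, so no shift beyond the scatter is expected. The step from compound 3 to compound 4 is estimated as a number 3.4 percentage points higher from compound 3 to compound 4 (within the scatter). Compound 4 is therefore expected to give about 5% in this assay, within a range from -8% to 18%.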

Compound 4, a percentage reported as inhibition, in the whole organism at one dose (the size of the read-out at that dose, not a potency): -3.5%
For compound 4 the middle estimate is 8.5 percentage points above the measured one, and the stated range covers the measured number.
By their numbers in this assay, from the lowest: compounds 4, 3, 1 and 2 (each within the scatter of the next, the first and the last beyond it).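

In this assay the swap of benzyl for 4-methylphenyl on the amide-type nitrogen, which keeps the same atoms joined differently, gives a number 5.1 percentage points lower from compound 3 to compound 4 (within the scatter) and so cannot be told apart from repeat scatter. Against the plain chains the 4-methylphenyl group does stand apart: replacing butyl gives a number 16.3 percentage points lower from compound 2 to compound 4 (beyond the scatter) and replacing methyl gives a number 13.1 percentage points lower from compound 1 to compound 4 (beyond the scatter) at this position, whereas benzyl was separated only from butyl. Nothing measured here accounts for these differences.

The compounds shown leave open whether any group on this nitrogen can lift the inhibition clear of these low numbers, for instance a longer chain such as octyl, or a chain ending in a carboxylic acid or an amine. They also leave open how these compounds behave at other doses, since every number comes from a single dose.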